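Swapping Hydroxyphenyl for Dichlorophenyl in Two Matched Pairs

A few compounds are considered here, and "the series" means these few. Any claim that something is new, unique, unknown or untested is made for them only; others in the source may bear on it.

Compound 1 `COc1cccc(/C=C2\CCC/C(=C\c3ccc(O)cc3)C2=O)c1OC` carries a 4-hydroxyphenyl group. In a functional assay on SW-620 cells (Homo sapiens) for cytotoxicity, read by MTT assay, with a stated time of 72 h (a lower number here means a stronger inhibitor, a higher number a weaker inhibitor), compound 1 gives > 20000 nM, which is a limit of the assay rather than a number; this is the limit of > 20000 nM in this assay, at which 1 of the 3 values shown sits. Compound 2 `COc1cccc(/C=C2\CCC/C(=C\c3cccc(Cl)c3Cl)C2=O)c1OC` differs by 2,3-dichlorophenyl in place of 4-hydroxyphenyl on a double-bonded chain carbon bound to a double-bonded ring carbon and in this assay gives 16300 nM, so that an at least 1.2-fold lower number from compound 1 to compound 2 (0.08 log units; that floor lies within the scatter). Compound 3 `COc1ccc(/C=C2\CCC/C(=C\c3ccc(O)cc3)C2=O)cc1OC` has the same atoms as compound 1 joined differently; the difference between the two cores is not broken down here. In this assay, within the data shown here, compound 3 gives 7700 nM, the lowest of the two numbers so far. Compound 4 `COc1ccc(/C=C2\CCC/C(=C\c3cccc(Cl)c3Cl)C2=O)cc1OC` is not yet measured; it differs from compound 3 by 2,3-dichlorophenyl in place of 4-hydroxyphenyl on a double-bonded chain carbon bound to a double-bonded ring carbon, the same change as that between compound 1 and compound 2. The earlier step of an at least 1.2-fold lower number from compound 1 to compound 2 (0.08 log units; that floor lies within the scatter) was small, and a similarly small step is expected here: a 1.3-fold lower number from compound 3 to compound 4 (0.11 log units; within the scatter). The estimate for compound 4 in this assay is 6000 nM, expected between 2500 nM and 15000 nM.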

Compound 4, half-maximal inhibitory concentration: 10800 nM
Compound 4: middle estimate off by 1.8-fold (0.26 log units), on the low side; the range from low to high includes it.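

In this assay, putting 2,3-dichlorophenyl in place of 4-hydroxyphenyl on the core of compound 3 gives a 1.4-fold higher number from compound 3 to compound 4 (0.15 log units; within the scatter). Set beside the same change on the other core, this does not settle whether the change carries over with the same size and direction: the same change on two cores in this assay, an at least 1.2-fold lower number (0.08 log units; that floor lies within the scatter) from compound 1 to compound 2 and a 1.4-fold higher number (0.15 log units; within the scatter) from compound 3 to compound 4; the limit leaves it open whether they differ The result shows that the change stays within the scatter on the core of compound 3, but it does not show how large the step on the core of compound 1 really is.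

The compounds shown leave open how a phenyl group bearing an amine or a carboxylic acid would read at this place. They also leave open whether either core would respond to such a group in the same way.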